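A few compounds are considered here, and "the series" means these few. Any claim that something is new, unique, unknown or untested is made for them only; others in the source may bear on it.

Measured so far:
compound 1 `COc1ccc(-c2[nH]c3ccccc3c2/C=C(\C#N)S(=O)(=O)c2ccccc2)cc1` — 871 nM
compound 2 `COc1ccc(-c2[nH]c3ccc(OC)cc3c2C=C(C#N)C#N)cc1` — 369 nM

In a functional assay on MOLT-4 cells (Homo sapiens) for inhibition, read by sulforhodamine B assay, with a stated time of 48 h (a higher number here means a weaker inhibitor of growth, a lower number a stronger inhibitor of growth), compound 1 holds the highest number of the two measured compounds; compound 2 sits at a lower number, and that gap lies beyond the scatter. Compound 3 `N#C/C(=C\c1c(-c2ccccc2)[nH]c2ccccc12)S(=O)(=O)c1ccccc1` differs from compound 1 by hydrogen in place of methoxy on an aromatic carbon. Among the compounds with values here, no measured pair shows this change, so the step from compound 1 to compound 3 can only be guessed; the step expected is small, and from compound 1 the number for compound 3 is estimated to move a 1.4-fold higher number from compound 1 to compound 3 (0.14 log units; within the scatter). The expected value for compound 3 in this assay is 1200 nM, within a range of 500 nM to 3000 nM.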

Compound 3, concentration for 50% growth inhibition: 2200 nM
Beside the measured number, compound 3's estimate is 1.8-fold (0.26 log units) below it; measured number inside the range.
By their numbers in this assay, from the lowest: compound 2; then compound 1; then compound 3.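

Replacing methoxy with hydrogen, which turns 4-methoxyphenyl into phenyl, gives a 2.5-fold higher number from compound 1 to compound 3 (0.40 log units; beyond the scatter) in this assay and this step lies beyond the scatter. This shows that the aromatic carbon para to a large group is a position where the substituent matters for growth inhibition, with methoxy the better of the two groups compared. Nothing measured here accounts for this step. The compounds shown leave open how an amine, a hydroxyl or an ethoxy would behave at this position, and whether the same change would carry over to the core of compound 2.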